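Pendant aryl groups on the benzyloxy chain of the shared core

This account rests on a few compounds, and the source may have more. Where it says the series, first, only, none or still open, it means among the compounds named here.

Measured so far:
- compound 1, `COc1ccc(COc2ccc(OCCOCCNC3CCCC3)cc2)cc1`: 15700 nM
- compound 2, `O=[N+]([O-])c1cccc(COc2ccc(OCCOCCNC3CCCC3)cc2)c1`: 15400 nM
- compound 3, `COc1ccc(OCCOCCNC2CCCC2)cc1`: 99100 nM

All three share the same core and differ only at the saturated chain carbon bound to an oxygen on the aromatic ring. In a functional assay on SK-OV-3 cells (Homo sapiens) for inhibition, read by CCK-8 assay, with a stated time of 70 h (on this read-out lower numbers stand for stronger inhibition and higher numbers for weaker inhibition), compound 3 gives the highest number of the three. The nearest of the others is compound 1 at a 6.3-fold higher number from compound 1 to compound 3 (0.80 log units; beyond the scatter); compound 2 lies at a 6.4-fold higher number from compound 2 to compound 3 (0.81 log units; beyond the scatter). Between compound 1 and compound 2 the change is a 1.0-fold lower number from compound 1 to compound 2 (0.01 log units; within the scatter), so the two aryl groups already seen are indistinguishable here.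

Compound 4, `O=C(O)c1ccc(COc2ccc(OCCOCCNC3CCCC3)cc2)cc1`, has yet to be measured. Its change from compound 3: 4-carboxyphenyl in place of hydrogen on a saturated chain carbon bound to an oxygen on an aromatic ring. The two steps that bear on it, 1>3 and 2>3, both removed an aryl group from this position and both raised the number by a modest margin. Reversing that direction, a modest decrease is expected for compound 4 in this assay, roughly a 5.8-fold lower number from compound 3 to compound 4 (0.77 log units; beyond the scatter), with the usual uncertainty of a new substituent. Compound 4 is therefore estimated at 17000 nM, within 6000 nM to 60000 nM.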

Compound 4, half-maximal inhibitory concentration: > 100000 nM
Compound 4: a limit, no number; the forecaster's own chance of this, stated with the estimate: 5%; middle value at least 5.8-fold (0.76 log units) away from the limit.
By their numbers in this assay, from the lowest: compounds 2 and 1 (each within the scatter of the next); then compound 3. At a limit, above all of these: compound 4.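

In this assay compound 4 stands only as a limit of the assay, not as a number: the limit of > 100000 nM in this assay, at which 1 of the 4 values shown sits. An aryl group at this position therefore does not lower the number on its own, since the 4-carboxyphenyl group gives an at least 6.4-fold higher number from compound 2 to compound 4 (0.81 log units; beyond the scatter) and carboxy in place of methoxy on an aromatic carbon gives an at least 6.3-fold higher number from compound 1 to compound 4 (0.80 log units; beyond the scatter), although the 3-nitrophenyl and 4-methoxyphenyl groups were indistinguishable. The size of the remaining step cannot be read: the added 4-carboxyphenyl group in place of hydrogen gives a number no lower from compound 3 to compound 4 (the limit leaves the size open).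

The compounds shown give no cause for this sensitivity to the ring substituent. Open, from the compounds shown here alone, is where a methyl ester or a primary amide in place of the carboxy, or a plain phenyl group on the saturated chain carbon, would fall.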